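The compounds below may be only part of what the source reports. "The series", "measured", "known", "first", "only" and "open" are said of these compounds alone.

Working notes on the series. For the measured compounds named here, compound 1 `CCCCOc1ccc2c(Cl)ccnc2c1` and compound 2 `C=CCOc1ccc2c(NCCN(C)C)ccnc2c1` are the two measured members. In a functional assay on BGC-823 cells (Homo sapiens) for cytotoxicity, read by MTT assay, with a stated time of 48 h (on this read-out higher numbers stand for weaker inhibition and lower numbers for stronger inhibition), compound 1 gives 3610 nM, and in this assay compound 2 gives 1360 nM. Going by the values given here, compound 2 therefore stands at the lowest of the two numbers, with compound 1 as its only neighbour, a gap beyond the usual scatter.

The next compound, compound 3 `C=CCOc1ccc2c(Cl)ccnc2c1`, is reached from compound 2 by a single change: chloro in place of (2-(dimethylamino)ethyl)amino on an aromatic carbon. Compound 1 also carries a chloro at the same place on the shared core and gives the higher of the two measured numbers, so the move to chloro is taken as the direction in which the number rises.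

For the step from compound 2 to compound 3 in this assay an upward move is expected, of roughly the size seen between the two measured compounds, and beyond the scatter: a 2.4-fold higher number from compound 2 to compound 3 (0.38 log units; beyond the scatter). In this assay compound 3 is thus estimated at 3300 nM, with a range from 1400 nM to 8000 nM.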

Compound 3, half-maximal inhibitory concentration: 2930 nM
Estimate against measurement, compound 3: 1.1-fold (0.05 log units) above, and the stated range covers the measured number.
By their numbers in this assay, from the lowest: compound 2; then compounds 3 and 1 (each within the scatter of the next).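

Compound 3 isolates the change at the position opposite the ring nitrogen, which compound 1 and compound 2 could not do as they differ in two places. In this assay chloro in place of (2-(dimethylamino)ethyl)amino gives a 2.2-fold higher number from compound 2 to compound 3 (0.33 log units; beyond the scatter) and this modest step lies beyond the scatter, so the number at this position responds to this exchange, with the lower number on the side of the (2-(dimethylamino)ethyl)amino compound. With chloro held fixed, vinyl in place of propyl on the chain bound to the oxygen gives a 1.2-fold lower number from compound 1 to compound 3 (0.09 log units; within the scatter) and this step stays within the scatter, so that exchange separates the two chloro compounds by no readable amount, and no data at hand give a reason for either step.

On these data alone, whether a shorter aminoethyl chain, a longer (3-(dimethylamino)propyl)amino chain or a morpholine ring at the chloro position would follow compound 2 remains open. As far as these compounds go, it is also open whether the step seen with the allyl ether carries over to the butyl ether of compound 1, or whether a carboxylic acid on that ether chain would change the picture.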